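Adding a Second Furan to a Compound at the Limit

This account rests on a few compounds, and the source may have more. Where it says the series, first, only, none or still open, it means among the compounds named here.

In a functional assay on HT-29 cells (Homo sapiens) for cytotoxicity (a lower number here means a stronger inhibitor, a higher number a weaker inhibitor), compound 2 `Nc1[nH]nc2nnc(-c3ccco3)cc12` gives > 100000 nM, which is a limit and not a measured number. Compound 1 `Nc1[nH]nc2nnc(-c3ccc(-c4ccccc4)cc3)c(-c3ccc(-c4ccccc4)cc3)c12` gives > 100000 nM, also a limit. Compound 3 `CC(=O)Nc1nn(C(C)=O)c2nnc(-c3ccccc3)c(-c3ccccc3)c12` gives > 100000 nM, again a limit. Among the compounds with values here, with only limits in hand, no measured step between these compounds can be read.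

Compound 4 `Nc1[nH]nc2nnc(-c3ccco3)c(-c3ccco3)c12` is compound 2 with a single change: furan-2-yl in place of hydrogen on an aromatic carbon. In words, furan-2-yl replaces hydrogen on an aromatic carbon, ortho to a furan-2-yl group.

No step beyond the usual scatter is expected in this assay, and compound 4 will probably stay at or near the same limit. This expectation rests on compound 2 at > 100000 nM and on the wider picture because of the limit of > 100000 nM in this assay, at which 3 of the 3 values shown sit. Compound 1 and compound 3 also carry an aromatic ring on that carbon, and neither gives a number.

The expected change is a number no higher from compound 2 to compound 4 (the limit leaves the size open), which is only an estimate. The estimated value for compound 4 is 100000 nM, with an expected range from 30000 nM to 150000 nM.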

Compound 4, half-maximal inhibitory concentration: > 100000 nM
Compound 4: no number, only a limit (the forecaster's own chance of this, stated with the estimate: 70%); the middle value sits exactly at the limit.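

In this assay compound 4 gives > 100000 nM, which is a limit and not a number. Within the data shown here, compound 2 also stands only at a limit, so no step between compound 2 and compound 4 can be read. The compounds shown leave open whether adding furan-2-yl changes the true value at all.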